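The source may hold more compounds than are shown below. What is called first, only, known or untested is meant among the compounds shown, and "the series" means these compounds.

Working notes on the series.

Compound 1 `OC[C@H]1O[C@@H](n2cnc3c(NCc4ccccc4F)ncnc32)[C@H](O)[C@@H]1O` has been run in a functional assay on G-361 cells (Homo sapiens) for antiproliferative activity, with a stated time of 72 h (a higher number here means a weaker inhibitor, a lower number a stronger inhibitor), and is recorded there as "not determined" (no result reported), so it stands on no number of its own within the set. For the measured compounds named here, the only measured member is compound 2 `COc1cccc(CNc2ncnc3c2ncn3[C@@H]2O[C@H](CO)[C@@H](O)[C@H]2O)c1O`, which in this assay gives 148000 nM, a very weak result. Compound 3 `OC[C@H]1O[C@@H](n2cnc3c(NCc4cc(O)cc(O)c4)ncnc32)[C@H](O)[C@@H]1O` has not yet been measured. Compound 3 differs from compound 1 by 3,5-dihydroxyphenyl in place of 2-fluorophenyl on a saturated chain carbon bound to a nitrogen on an aromatic ring; the hydrogen-bond donors and acceptors entering with the 3,5-dihydroxyphenyl are the whole of the change. Going by the values given here, no step between measured compounds is available, so nothing measured anchors the size of this step. For compound 3 the expectation in this assay is a weak result of the same order as compound 2, with the step from compound 1 unknown in direction. Compound 3 is expected to give about 120000 nM, with a range from 40000 nM to 400000 nM, and a limit rather than a number is plausible.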

Compound 3, half-maximal inhibitory concentration: > 166000 nM
Compound 3: a limit, no number; the forecaster's own chance of this, stated with the estimate: 40%; middle value at least 1.3-fold (0.14 log units) away from the limit.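

In this assay compound 3 is recorded only as a limit, > 166000 nM, and not as a number. From the compounds shown here alone, with 3,5-dihydroxyphenyl in place of 2-hydroxy-3-methoxyphenyl on a saturated chain carbon bound to a nitrogen on an aromatic ring, the step reads an at least 1.1-fold higher number from compound 2 to compound 3 (0.04 log units; that floor lies within the scatter), so a second hydroxylated phenyl at this place also gives no strong result, while the true size of the step stays unknown. The reading at this position therefore stops at a limit: the limit of > 166000 nM in this assay, at which 1 of the 3 values shown sits.

Going by these compounds, the step from compound 1 cannot be read, since compound 1 has no number, and the effect of 2-fluorophenyl at this place stays open. Also open, on these data alone, is whether an amine or a carboxylic acid in place of the 3,5-dihydroxyphenyl would give a measurable number in this assay.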